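The source may report more compounds than this note shows. Statements on the series, on what has been measured and on what is new or still open speak of the compounds shown alone.

Measured so far:
Compound 1, `NNC(=O)c1c(NC(=O)NS(=O)(=O)c2ccccc2)sc2c1CCCCC2`: in a functional assay on cells (Cancer cell lines, Homo sapiens) for inhibition, with a stated time of 48 h (a lower number here means a stronger inhibitor of growth, a higher number a weaker inhibitor of growth), compound 1 returns only a limit, > 100000 nM.
Compound 2, `O=C(Nc1sc2c(c1C(=O)NNc1ccc(Br)cc1)CCCCC2)NS(=O)(=O)c1ccccc1`: in this assay compound 2 gives 11500 nM.
Compound 3, `O=C(Nc1sc2c(c1C(=O)NNc1ccc(Cl)cc1)CCCCC2)NS(=O)(=O)c1ccccc1`: in this assay compound 3 also returns only a limit, > 100000 nM.

Compound 3 therefore stands at the limit, and so does one other member, as the limit of > 100000 nM in this assay, at which 2 of the 3 values shown sit, records. Among the measured compounds shown here, compound 2 is the only compound with a number; an at least 8.6-fold higher number from compound 2 to compound 3 (0.93 log units; beyond the scatter), while an at least 8.6-fold lower number from compound 1 to compound 2 (0.93 log units; beyond the scatter). Between the two limit-bearing compounds, a step that the two limits leave unreadable from compound 1 to compound 3. The true position of compound 3 is open: it may sit at the limit or well past it.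

Compound 4, `O=C(Nc1sc2c(c1C(=O)N1CCN(c3ccccc3)CC1)CCCCC2)NS(=O)(=O)c1ccccc1`, differs from compound 3 in one place: 4-phenylpiperazin-1-yl in place of ((4-chlorophenyl)amino)amino on a carbonyl carbon. For the measured compounds named here, none of the measured steps exchanges the whole amine-bearing group at this carbonyl for a ring attached through nitrogen, so none bears on it directly; they show only that a change at this carbonyl carbon can move the number beyond the scatter in either direction. With compound 3 itself at the limit, the direction of the step cannot be fixed. Compound 4 is estimated at 30000 nM, with a range from 4000 nM to 100000 nM. The expected step, set against the limit, is an at least 3.3-fold lower number from compound 3 to compound 4 (0.52 log units; beyond the scatter).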

Compound 4, concentration for 50% growth inhibition: 65200 nM
The estimate for compound 4 lay 2.2-fold (0.34 log units) below the measured number, within the range that was stated.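

Among the compounds shown here, with 4-phenylpiperazin-1-yl on this carbonyl carbon, the series gains a second number, which allows the first readable comparison of this group with ((4-bromophenyl)amino)amino: a 5.7-fold higher number from compound 2 to compound 4 (0.75 log units; beyond the scatter). Against the other two groups only a floor can be read: an at least 1.5-fold lower number from compound 3 to compound 4 (0.18 log units; that floor lies within the scatter), and an at least 1.5-fold lower number from compound 1 to compound 4 (0.18 log units; that floor lies within the scatter). Compound 4 thus shows that a measurable number at this carbonyl carbon does not depend on the hydrogen-bond donors of the groups in compound 2 and compound 3, as 4-phenylpiperazin-1-yl has none, though compound 2 keeps the lower number.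

On these data alone, how a morpholin-4-yl group or a piperidin-1-yl group would read on this carbonyl carbon remains open. How far compound 1 and compound 3 lie past their values also remains open, as both are limits: the limit of > 100000 nM in this assay, at which 2 of the 4 values shown sit.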